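The compounds below may be only part of what the source reports. "The series", "measured", "known", "first", "only" and "open" are said of these compounds alone.

Compound 1 `COc1ccc(-c2cc(O)c3cccnc3n2)cc1` was tested in a functional assay on MDA-MB-435 cells (Homo sapiens) (a higher number here means a weaker inhibitor of growth, a lower number a stronger inhibitor of growth), and gives 20000 nM. Its methylated partner, compound 2 `COc1ccc(-c2cc(O)c3cc(C)cnc3n2)cc1`, gives 1820 nM in this assay. The change between them is methyl in place of hydrogen on an aromatic carbon, and it made a large step: an 11-fold lower number from compound 1 to compound 2 (1.04 log units; beyond the scatter).

Compound 3 `COc1ccccc1-c1cc(O)c2cccnc2n1` is built from the same atoms as compound 1, joined differently; the difference between the two cores is not broken down here. In this assay compound 3 gives 39800 nM, a number that lies within the scatter of the value of compound 1, so nothing can be said about an order between those two.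

Compound 4 `COc1ccccc1-c1cc(O)c2cc(C)cnc2n1` is not yet measured. It stands to compound 3 as compound 2 stands to compound 1: the change is methyl in place of hydrogen on an aromatic carbon, the same change, at the same place. Among the measured compounds shown here, because the only earlier example, an 11-fold lower number from compound 1 to compound 2 (1.04 log units; beyond the scatter), was large, compound 4 is expected to fall well below compound 3. The expected step is a 10-fold lower number from compound 3 to compound 4 (1.00 log units; beyond the scatter), resting on one pair only, so the range is kept wide. Compound 4 is estimated at 4000 nM, between 1200 nM and 15000 nM.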

Compound 4, concentration for 50% growth inhibition: 3020 nM
Estimate against measurement, compound 4: 1.3-fold (0.12 log units) above; measured number inside the range.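

In this assay, methyl in place of hydrogen on an aromatic carbon gave a 13-fold lower number from compound 3 to compound 4 (1.12 log units; beyond the scatter), and the step carried from one core to the other with no difference that the data can separate: the same change on two cores in this assay, an 11-fold lower number (1.04 log units; beyond the scatter) from compound 1 to compound 2 and a 13-fold lower number (1.12 log units; beyond the scatter) from compound 3 to compound 4, 1.2-fold (0.08 log units) apart, within the scatter of two such steps. For these two cores, which are built from the same atoms joined differently, the size of the step therefore held at this one place on the ring. This does not show that the step would hold on any other core or at any other place, as the comparison rests on just two pairs in a single assay, and it does not say why the number falls.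

The compounds shown carry only methyl at this place, so it remains open whether an ethyl group, a longer chain, an amine or a carboxylic acid there would lower the number as far, or at all. Going by these compounds, whether the same step would appear outside this assay also remains open.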